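The compounds below may be only part of what the source reports. "The series", "measured", "known", "first", "only" and "open" are said of these compounds alone.

Measured so far in a functional assay on thoracic aorta (Rattus norvegicus, strain Wistar), with a stated time of 15 min; on this read-out lower numbers stand for an effect already at smaller amounts and higher numbers for an effect only at larger amounts of compound:

Compound 1 `CCOc1ccc(Cl)cc1C(C)NC(=O)NS(=O)(=O)c1ccc(C)cc1`: > 300000 nM
Compound 2 `COc1ccc(Cl)cc1C(C)NC(=O)NS(=O)(=O)c1ccc(Cl)cc1`: > 300000 nM
Compound 3 `COc1ccc(F)cc1C(C)NC(=O)NS(=O)(=O)c1ccc(C)cc1`: > 300000 nM

All three readings are limits of the assay and not numbers, so no potency order can be drawn among these compounds. Compound 3 stands with the other two: its > 300000 nM is a limit, as the shared the limit of > 300000 nM in this assay, at which 3 of the 3 values shown sit, shows.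

Compound 4 `COc1ccc(Cl)cc1C(C)NC(=O)NS(=O)(=O)c1ccc(C)cc1` has not yet been measured. It differs from compound 3 by chloro in place of fluoro on an aromatic carbon, with chloro in place of fluoro on an aromatic carbon, para to a methoxy group.

Chloro in that place is already carried by compound 1, whose > 300000 nM is a limit. Compound 2 also carries it, and its > 300000 nM is a limit too. In this assay, no step beyond the scatter is therefore expected, and another limit is the likeliest report. The expected step, a number no higher from compound 3 to compound 4 (the limit leaves the size open), is correspondingly small and has no firm direction. For compound 4 the estimated value is 300000 nM, with an expected range from 120000 nM to 500000 nM.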

Compound 4, half-maximal effective concentration: > 300000 nM
Compound 4 was reported as a limit (the forecaster's own chance of this, stated with the estimate: 75%); the middle value sits exactly at the limit.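

Compound 4 is also reported only as a limit in this assay, so no step from compound 1, compound 2 or compound 3 to compound 4 can be read: the limit of > 300000 nM in this assay, at which 4 of the 4 values shown sit.

The compounds shown leave open how these four rank in this assay, and whether any change to the shared core would give a readable value there.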